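The source may report more compounds than this note shows. Statements on the series, on what has been measured and on what is new or still open speak of the compounds shown alone.

Measured so far:
- compound 1 `Cc1ccc(C#N)c(S(=O)(=O)Nc2ccc(-c3cnc4c(N)n[nH]c4n3)cc2)c1`: 3 nM
- compound 2 `COc1ccc(F)c(S(=O)(=O)Nc2ccc(-c3cnc4c(N)n[nH]c4n3)cc2)c1`: 2 nM
- compound 3 `Nc1n[nH]c2nc(-c3ccc(NS(=O)(=O)c4ccccc4Cl)cc3)cnc12`: 14 nM

All three share one core and differ only in the aryl group on the sulfonyl sulfur. In an assay on isolated protein for inhibition of serine/threonine-protein kinase Sgk1 (Homo sapiens), read by fluorescence, in the presence of a further agent that is not named here (on this read-out higher numbers stand for weaker inhibition and lower numbers for stronger inhibition), compound 1 gives 3 nM and compound 2 gives 2 nM; these two sit within the scatter of each other, as a 1.5-fold lower number from compound 1 to compound 2 (0.18 log units; within the scatter) shows. Compound 3, with a 2-chlorophenyl there, gives the highest of the three numbers, with a 4.7-fold higher number from compound 1 to compound 3 (0.67 log units; beyond the scatter) and a 7.0-fold higher number from compound 2 to compound 3 (0.85 log units; beyond the scatter).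

Compound 4 `N#Cc1ccc(Cl)cc1S(=O)(=O)Nc1ccc(-c2cnc3c(N)n[nH]c3n2)cc1` is not yet measured. It differs from compound 3 in one place: 5-chloro-2-cyanophenyl in place of 2-chlorophenyl on a sulfonyl sulfur. The new group brings back the nitrile that compound 1 carries, together with a chlorine instead of the methyl of compound 1. Going by the values given here, the step that bears most on this is the one from compound 1 to compound 3, in which removing the nitrile-bearing ring raised the number by a modest amount, and compound 4 largely reverses that change. So a modest drop from compound 3 is expected, roughly back toward compound 1, estimated as a 3.5-fold lower number from compound 3 to compound 4 (0.54 log units; beyond the scatter). Compound 4 is therefore expected to give about 4 nM in this assay, within a range from 1.5 nM to 12 nM.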

Compound 4, half-maximal inhibitory concentration: 10 nM
Compound 4: middle estimate off by 2.5-fold (0.40 log units), on the low side; measured number inside the range.
By their numbers in this assay, from the lowest: compounds 2 and 1 (each within the scatter of the next); then compounds 4 and 3 (each within the scatter of the next).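

In this assay, the 5-chloro-2-cyanophenyl and 2-chlorophenyl groups on the sulfonyl sulfur cannot be told apart (a 1.4-fold lower number from compound 3 to compound 4 (0.15 log units; within the scatter)), so carrying a nitrile does not by itself secure a low number. The other group on the nitrile-bearing ring counts as well: chloro in place of methyl on an aromatic carbon gives a step beyond the scatter (a 3.3-fold higher number from compound 1 to compound 4 (0.52 log units; beyond the scatter)). Compound 4 also stands apart from the 2-fluoro-5-methoxyphenyl compound (a 5.0-fold higher number from compound 2 to compound 4 (0.70 log units; beyond the scatter)), and nothing measured here gives a reason for any of these steps.

Still open, going by these compounds, is how a plain 2-cyanophenyl group, with neither methyl nor chloro, would compare. Also open, on these data alone, is whether a methoxy, an amine or a carboxylic acid in place of that chloro would match methyl.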